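Swapping a ring for a branched chain on a double-bonded nitrogen

The source may hold more compounds than are shown below. What is called first, only, known or untested is meant among the compounds shown, and "the series" means these compounds.

Measured compounds:
compound 1 `N#CN/C(=N\C1CCCC1)Nc1cc(Cl)cc(Cl)c1`: 75000 nM
compound 2 `C[C@H](/N=C(\NC#N)Nc1cc(Cl)cc(Cl)c1)c1ccccc1`: 30000 nM
compound 3 `N#CN/C(=N\C1CCCC1)Nc1cc(C(F)(F)F)cc(C(F)(F)F)c1`: > 300000 nM

All three were tested in a functional assay (aorta) with Rattus norvegicus as the target; on this read-out lower numbers stand for stronger inhibition and higher numbers for weaker inhibition. Compound 1 gives 75000 nM and compound 2 gives 30000 nM. For compound 3 the result > 300000 nM is a limit of the assay, not a number. Compound 3 thus sits at the limit of > 300000 nM in this assay, at which 1 of the 3 values shown sits, the weak end of what is shown.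

Compound 4 `CC(C)C(C)/N=C(\NC#N)Nc1cc(C(F)(F)F)cc(C(F)(F)F)c1` differs from compound 3 in one place: 1,2-dimethylpropyl in place of cyclopentyl on a double-bonded nitrogen. Among the measured compounds shown here, no measured pair shows this change. The step is expected to be a number no higher from compound 3 to compound 4 (the limit leaves the size open), in neither direction beyond the usual scatter. Compound 4 is therefore estimated at about 300000 nM, between 80000 nM and 1500000 nM, quite possibly again reported only as a limit.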

Compound 4, half-maximal inhibitory concentration: 17600 nM
Beside the measured number, compound 4's estimate is 17-fold (1.23 log units) above it, outside the stated range (below it).
By their numbers in this assay, from the lowest: compounds 4 and 2 (each within the scatter of the next); then compound 1. At a limit, above all of these: compound 3.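

In this assay, opening the cyclopentyl ring into 1,2-dimethylpropyl, with the same count of carbons, gives an at least 17-fold lower number from compound 3 to compound 4 (1.23 log units; beyond the scatter). This position therefore responds strongly to the shape of the group, and for this pair a ring is not needed for a measurable result. Compound 3 itself stands only at a limit of the assay: the limit of > 300000 nM in this assay, at which 1 of the 4 values shown sits.

Going by these compounds, whether the same swap would lower the number on the core of compound 1 stays open. So does how a longer chain or an amine would read at this position.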